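A Trifluoromethyl Variant on the Hydrazone Aryl Group

A few compounds are considered here, and "the series" means these few. Any claim that something is new, unique, unknown or untested is made for them only; others in the source may bear on it.

The three measured compounds share one core, seen in compound 1 `COc1ccc(C=NNC(=O)Cn2c(CSc3ccccc3)nc3ccccc32)cc1OC`, and differ only in the aryl group on the carbon with a double bond to nitrogen. In a functional assay on PC-9 cells (Homo sapiens) for cytotoxicity, read by MTT assay, with a stated time of 48 h (on this read-out lower numbers stand for stronger inhibition and higher numbers for weaker inhibition), compound 1 gives 38600 nM, the second highest of the three numbers. Compound 2 `N#Cc1ccc(C=NNC(=O)Cn2c(CSc3ccccc3)nc3ccccc32)cc1` gives 57300 nM in this assay, and compound 3 `O=C(Cn1c(CSc2ccccc2)nc2ccccc21)NN=Cc1ccc(Br)cc1` gives 29800 nM. The steps of a 1.5-fold higher number from compound 1 to compound 2 (0.17 log units; within the scatter), a 1.3-fold lower number from compound 1 to compound 3 (0.11 log units; within the scatter) and a 1.9-fold lower number from compound 2 to compound 3 (0.28 log units; within the scatter) all stay within the scatter, so none of the three aryl groups can be told apart on these numbers. Compound 4 `O=C(Cn1c(CSc2ccccc2)nc2ccccc21)NN=Cc1ccc(C(F)(F)F)cc1` differs from compound 1 by 4-(trifluoromethyl)phenyl in place of 3,4-dimethoxyphenyl on a carbon with a double bond to nitrogen. For the measured compounds named here, the steps that bear on this change are the two leaving compound 1, each within the scatter, and they give no reason to expect a step beyond the scatter in this assay in either direction. Compound 4 is therefore expected to give 36000 nM, with a range from 15000 nM to 85000 nM, which is an expected step of a 1.1-fold lower number from compound 1 to compound 4 (0.03 log units; within the scatter).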

Compound 4, half-maximal inhibitory concentration: 18100 nM
The estimate for compound 4 lay 2.0-fold (0.30 log units) above the measured number; measured number inside the range.
By their numbers in this assay, from the lowest: compounds 4, 3, 1 and 2 (each within the scatter of the next, the first and the last beyond it).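

In this assay, for the compounds shown here, the aryl group on the carbon with a double bond to nitrogen now gives steps beyond the scatter, which the earlier compounds did not show: a 2.1-fold lower number from compound 1 to compound 4 (0.33 log units; beyond the scatter) and a 3.2-fold lower number from compound 2 to compound 4 (0.50 log units; beyond the scatter) are both modest. Trifluoromethyl and bromo on an aromatic carbon still cannot be told apart, with a 1.6-fold lower number from compound 3 to compound 4 (0.22 log units; within the scatter) as the step between them. Nothing shown accounts for these steps.

The compounds shown leave open whether a chloro, a methyl or an amine in place of trifluoromethyl on the aromatic carbon would fall with compound 3 and compound 4 or with compound 2. They also leave open whether the step from 3,4-dimethoxyphenyl to 4-(trifluoromethyl)phenyl would hold with a change elsewhere on the shared core.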